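Adding a Third Methoxy Group to Compound 2

A few compounds are considered here, and "the series" means these few. Any claim that something is new, unique, unknown or untested is made for them only; others in the source may bear on it.

Compound 1 `Cc1cc(O)c(C2=NN(c3ccc(S(N)(=O)=O)cc3)C(c3ccccc3O)C2)cc1Cl` was tested in a functional assay on RXF 393 cells (Homo sapiens) for antiproliferative activity, with a stated time of 48 h (a higher number here means a weaker inhibitor of growth, a lower number a stronger inhibitor of growth), where compound 1 gives 3650 nM. Compound 2 `COc1ccc(C2CC(c3cc(Cl)c(C)cc3O)=NN2c2ccc(S(N)(=O)=O)cc2)cc1OC` differs from it in that a 3,4-dimethoxyphenyl stands in place of the 2-hydroxyphenyl on a saturated ring carbon; in this assay compound 2 gives 2880 nM. Of the two numbers, compound 2 has the lower, but a 1.3-fold lower number from compound 1 to compound 2 (0.10 log units; within the scatter), so the two compounds cannot be told apart. Compound 3 `COc1ccc(C2CC(c3cc(Cl)c(C)cc3O)=NN2c2ccc(S(N)(=O)=O)cc2)c(OC)c1OC` carries one more change on the same aryl group: methoxy in place of hydrogen on an aromatic carbon. Within the data shown here, the only measured step that bears on this ring, a 1.3-fold lower number from compound 1 to compound 2 (0.10 log units; within the scatter), did not move this assay beyond the scatter, and no step adding a methoxy group has been measured. For compound 3 a step of about a 1.0-fold lower number from compound 2 to compound 3 (0.01 log units; within the scatter) is therefore expected, no larger than the scatter. Compound 3 is estimated to give 2800 nM, within a range from 1200 nM to 6500 nM.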

Compound 3, concentration for 50% growth inhibition: 2900 nM
Compound 3: the middle estimate sits 1.0-fold (0.02 log units) below what was measured, and the stated range covers the measured number.
By their numbers in this assay, from the lowest: compounds 2, 3 and 1 (each within the scatter of the next).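

In this assay, methoxy in place of hydrogen on an aromatic carbon, ortho to a large group and ortho to a methoxy group, gives a 1.0-fold higher number from compound 2 to compound 3 (0.00 log units; within the scatter) and so leaves the number unchanged within the scatter at this position. Taken from the 2-hydroxyphenyl compound, the 2,3,4-trimethoxyphenyl group gives a 1.3-fold lower number from compound 1 to compound 3 (0.10 log units; within the scatter) as well, so the aryl groups of all three compounds remain indistinguishable in this assay. Nothing available gives any measurement that would account for this result.

Still open, going by these compounds, is whether a group of another kind on this aromatic carbon, such as an amine or a carboxylic acid, would shift the number beyond the scatter. On these data alone, it is also open whether a longer chain, such as propoxy, in place of the methoxy group would do so.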